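Selenophene quinolones: removing the hydroxy from the methyl analogue

This account rests on a few compounds, and the source may have more. Where it says the series, first, only, none or still open, it means among the compounds named here.

Measured so far in a functional assay on Hep 3B2 cells (Homo sapiens) for cytotoxicity, read by MTT assay, with a stated time of 48 h; a lower number here means a stronger inhibitor, a higher number a weaker inhibitor:
compound 1 `COc1ccc2[nH]c(-c3ccc[se]3)cc(=O)c2c1O` gives 700 nM
compound 2 `COc1ccc2[nH]c(-c3ccc[se]3)cc(=O)c2c1` gives 3200 nM
compound 3 `COc1ccc2[nH]c(-c3ccc(C)[se]3)cc(=O)c2c1O` gives 800 nM

Compound 4 `COc1ccc2[nH]c(-c3ccc(C)[se]3)cc(=O)c2c1` has not been measured. The two cores differ as follows: methyl in place of hydrogen on an aromatic carbon That change gave a 1.1-fold higher number from compound 1 to compound 3 (0.06 log units; within the scatter), so compound 1 and compound 3 sit together.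

The change from compound 3 to compound 4 is hydrogen in place of hydroxy on an aromatic carbon The same change was made once before, from compound 1 to compound 2: hydrogen in place of hydroxy on an aromatic carbon The two place descriptions agree word for word, so this is the same change. Its measured step was a 4.6-fold higher number from compound 1 to compound 2 (0.66 log units; beyond the scatter)

On the strength of that earlier step, the step from compound 3 to compound 4 is expected to be of similar size, a 4.6-fold higher number from compound 3 to compound 4 (0.67 log units; beyond the scatter), because compound 3 starts from 800 nM and the only comparable case, compound 1 to compound 2, gave a 4.6-fold higher number from compound 1 to compound 2 (0.66 log units; beyond the scatter) That rests on a single prior example, so the expectation carries a wide band. Compound 4 is estimated at 3700 nM, with a likely range from 1500 nM to 9000 nM.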

Compound 4, half-maximal inhibitory concentration: 3000 nM
For compound 4 the middle estimate is 1.2-fold (0.09 log units) above the measured one; the measured number falls inside the stated range.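

In this assay, hydrogen in place of hydroxy on the methyl-bearing core gives a 3.8-fold higher number from compound 3 to compound 4 (0.57 log units; beyond the scatter), and this step carries over from the core of compound 1 with no difference that can be read: the same change on two cores in this assay, a 4.6-fold higher number (0.66 log units; beyond the scatter) from compound 1 to compound 2 and a 3.8-fold higher number (0.57 log units; beyond the scatter) from compound 3 to compound 4, 1.2-fold (0.09 log units) apart, within the scatter of two such steps. The methyl group leaves the number without the hydroxy within the scatter, with a 1.1-fold lower number from compound 2 to compound 4 (0.03 log units; within the scatter), matching what it did with the hydroxy present: the same change on two cores in this assay, a 1.1-fold higher number (0.06 log units; within the scatter) from compound 1 to compound 3 and a 1.1-fold lower number (0.03 log units; within the scatter) from compound 2 to compound 4, 1.2-fold (0.09 log units) apart, within the scatter of two such steps. Across these four compounds the two changes therefore behave independently, but that rests on just two pairs per change and shows neither why the hydroxy matters nor that the step would hold on a core carrying anything other than hydrogen or methyl at that place.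

The compounds shown leave open whether another group in place of the hydroxy, such as an amine or a fluorine, would keep the numbers of compound 1 and compound 3. On these data alone, it is also open whether a longer chain or a carboxylic acid in place of the methyl would stay within the scatter as the methyl does.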